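A few compounds are considered here, and "the series" means these few. Any claim that something is new, unique, unknown or untested is made for them only; others in the source may bear on it.

Compound 1 `CN(C)c1nccc2c1ncn2[C@H]1C[C@H](O)[C@@H](CO)O1` gives < 5% in this study. Compound 2 `OCCNc1nccc2c1ncn2C1O[C@H](CO)[C@@H](O)[C@H]1O` gives 6%. Compound 3 `CNc1[nH]ccc2ncnc1-2` gives < 5%.

In a functional assay on EL4 cells (Mus musculus) for inhibition, tested at 100 uM (a higher number here means more inhibition at the concentration tested (going by the name of the read-out), a lower number less inhibition), compound 1 reaches only a limit of the assay, < 5%, and not a number. Compound 3 likewise sits at a limit, < 5%. Compound 2 gives a number, 6%. Across the three measured compounds the picture is the limit of < 5% in this assay, at which 2 of the 3 values shown sit. Compound 4 `OC[C@H]1O[C@@H](n2cnc3c(SCc4ccccc4)nccc32)C[C@@H]1O` differs from compound 1 in one place: benzylsulfanyl in place of dimethylamino on an aromatic carbon. Among the compounds with values here, no step between measured compounds is available to size this change, so the step from compound 1 to compound 4 is expected to stay within the scatter, a number no lower from compound 1 to compound 4 (the limit leaves the size open). Compound 4 is estimated at 5%, between 0% and 18%, most likely again reported as a limit.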

Compound 4, a percentage reported as inhibition, at one concentration (the size of the read-out at that concentration, not a potency): 11%
Compound 4: the middle estimate sits 6 percentage points below what was measured; measured number inside the range.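

In this assay, benzylsulfanyl in place of dimethylamino on an aromatic carbon, next to the ring nitrogen, gives a number at least 6 percentage points higher from compound 1 to compound 4 (that floor lies within the scatter). Compound 4 gives a number, 11%, so this position takes a group with a six-membered aromatic ring of carbon only and the read-out stays measurable. Compound 1, at < 5%, sits at a limit of the assay, which leaves the size of the step open.

The compounds shown leave open whether a benzylamine or a carboxylic acid at this place would carry the read-out beyond the scatter. They also offer little to compare against: the limit of < 5% in this assay, at which 2 of the 4 values shown sit.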